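Chloro in Place of Methyl: An Expected Cytotoxicity Read-Out

A few compounds are considered here, and "the series" means these few. Any claim that something is new, unique, unknown or untested is made for them only; others in the source may bear on it.

Compound 1 `Cc1ccc(-c2cs/c(=N/NC(=O)CSc3nnnn3-c3ccccc3)n2-c2ccccc2)cc1`: 22.2%
Compound 2 `COc1ccc(-c2cs/c(=N/NC(=O)CSc3ncccn3)n2-c2ccccc2)cc1`: 37.6%

Of the compounds shown here, two have been measured in a functional assay on C6 cells (Rattus norvegicus) for cytotoxicity, read by MTT assay, with a stated time of 24 h, tested at 200 ug/mL; on this read-out higher numbers stand for a weaker effect at the one concentration tested and lower numbers for a stronger effect. Compound 1 gives 22.2%, and compound 2 gives 37.6%. On these two numbers compound 1 stands lowest, the stronger effect of the pair; compound 2 sits higher by a gap that lies beyond the scatter. The two compounds differ in more than one place, so their gap cannot be tied to any single change.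

Compound 3 `O=C(CSc1nnnn1-c1ccccc1)N/N=c1/scc(-c2ccc(Cl)cc2)n1-c1ccccc1` has not yet been measured. It differs from compound 1 in one place: chloro in place of methyl on an aromatic carbon. Everything else in the molecule stays as in compound 1.

Going by the values given here, no measured pair differs in exactly one place, so there is no measured step to lean on. Putting chloro in place of methyl on an aromatic carbon is expected to move the read-out in this assay only slightly and with no clear direction, so the step of a number 0.8 percentage points higher from compound 1 to compound 3 (within the scatter) is expected to stay within the scatter. Because compound 1 shows 22.2%, compound 3 is expected to give 23%, with a range from 10% to 38%.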

Compound 3, a percentage reported as activity, at one concentration (the size of the read-out at that concentration, not a potency): 52.4%
The estimate for compound 3 lay 29.4 percentage points below the measured number; measured number above the stated range.
By their numbers in this assay, from the lowest: compound 1; then compound 2; then compound 3.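

Within this assay, replacing 4-methylphenyl with 4-chlorophenyl gives a number 30.2 percentage points higher from compound 1 to compound 3 (beyond the scatter), which means a weaker effect at the one concentration tested. Going by these compounds alone, this is the first comparison here in which only one place changes, and it shows that this position, para to a large group on the six-membered aromatic ring, is far from indifferent: exchanging one heavy atom for another, with no change in the counted hydrogen-bond donors or acceptors, is enough to shift the read-out well beyond the scatter. No measurement shown here accounts for the size or direction of this shift.

A single step cannot show whether methyl is unusually favourable at this position or chloro unusually unfavourable, and the wider trend remains undefined until other groups, such as fluoro, an amine, a carboxylic acid or a longer alkyl chain, are compared in the same place. On these data alone, it also remains open whether the same exchange would have a similar effect on a different core, or at concentrations other than the single one used here.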